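The source may hold more compounds than are shown below. What is called first, only, known or untested is meant among the compounds shown, and "the series" means these compounds.

Three compounds of one series were tested in a functional assay on KB cells (Homo sapiens) for cytotoxicity, read by sulforhodamine B assay (on this read-out higher numbers stand for an effect only at larger amounts of compound and lower numbers for an effect already at smaller amounts), and a fourth awaits its result. Compound 1 `C=C1CC[C@@H]2[C@](C)(COC(C)=O)[C@H](OC(C)=O)CC[C@@]2(C)[C@@H]1C/C=C1/C(=O)OC[C@H]1OC(C)=O` gives 11.6 uM in this assay. Compound 2 `C=C1CC[C@@H]2[C@](C)(CO[Si](C(C)C)(C(C)C)C(C)C)[C@H](OC(C)=O)CC[C@@]2(C)[C@@H]1C/C=C1/C(=O)OC[C@H]1OC(C)=O` gives 7.39 uM. Compound 3 `C=C1CC[C@@H]2[C@](C)(CO[Si](C(C)C)(C(C)C)C(C)C)[C@H](O)CC[C@@]2(C)[C@@H]1C/C=C1/C(=O)OC[C@H]1O` gives 2.73 uM, the lowest of the three numbers, with compound 2 nearest to it and compound 1 furthest away; how the core of compound 3 differs from that of compound 2 is not broken down here.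

Compound 2 and compound 1 differ in one place: a group of 3 heavy atoms (2 carbon, 1 oxygen; no ring) in place of a group of 10 heavy atoms (9 carbon, 1 silicon; no ring), on an oxygen on a saturated carbon. This change produced a 1.6-fold higher number from compound 2 to compound 1 (0.20 log units; within the scatter).

Compound 4 `C=C1CC[C@@H]2[C@](C)(COC(C)=O)[C@H](O)CC[C@@]2(C)[C@@H]1C/C=C1/C(=O)OC[C@H]1O` is not yet measured. It is related to compound 3 by the same change: a group of 3 heavy atoms (2 carbon, 1 oxygen; no ring) in place of a group of 10 heavy atoms (9 carbon, 1 silicon; no ring), on an oxygen on a saturated carbon. Since the earlier step from compound 2 to compound 1 stayed within the scatter, a similarly small shift from compound 3 to compound 4 is expected, a 1.6-fold higher number from compound 3 to compound 4 (0.21 log units; within the scatter), because compound 3 gives 2.73 uM and the prior step is a 1.6-fold higher number from compound 2 to compound 1 (0.20 log units; within the scatter). Compound 4 is therefore estimated to give 4.4 uM in this assay, expected to fall between 2 uM and 9.5 uM.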

Compound 4, concentration for half-maximal effect: 15.3 uM
Compound 4: the middle estimate sits 3.5-fold (0.54 log units) below what was measured; the whole stated range lies below it.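

In this assay, putting acetyl in place of the silicon-bearing group of 10 heavy atoms on an oxygen on a saturated carbon gave a 5.6-fold higher number from compound 3 to compound 4 (0.75 log units; beyond the scatter) on the core of compound 3, and so the change did not carry over with the same size from one core to the other: the same change on two cores in this assay, a 1.6-fold higher number (0.20 log units; within the scatter) from compound 2 to compound 1 and a 5.6-fold higher number (0.75 log units; beyond the scatter) from compound 3 to compound 4, 3.6-fold (0.55 log units) apart, beyond the scatter of two such steps

In this series, then, the size of this change cannot be taken from one core and applied unchanged to another, at least for these two pairs. What the two pairs do not show is which difference between the cores lies behind the gap, or how the same change would read on any further core, since two steps set no general rule.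

The compounds shown leave open how other groups on that oxygen would read, such as a free hydroxyl, a methyl ether, a longer acyl chain or a chain carrying an amine. They also leave open whether such groups would follow the step seen on the core of compound 1 or the one seen on the core of compound 3.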